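The compounds below may be only part of what the source reports. "The series", "measured", "known", "first", "only" and "open" are said of these compounds alone.

In an ADME assay on 184B5 cells (Homo sapiens) for cytotoxicity, read by MTT assay, with a stated time of 72 h (a higher number here means a weaker inhibitor of growth, a lower number a stronger inhibitor of growth), compound 2 `CCOC(=O)Nc1ccc([Se]C#N)cc1` gives 5500 nM, the highest of the two numbers in hand. Its nearest neighbour is compound 1 `CCCCCCOC(=O)Nc1ccc([Se]C#N)cc1`, which in this assay gives 4600 nM. Going by the values given here, the single measured step, a 1.2-fold higher number from compound 1 to compound 2 (0.08 log units; within the scatter), alters the same saturated chain bound to the oxygen next to the carbonyl group and stays within the scatter. Compound 3 `N#C[Se]c1ccc(NC(=O)OCc2ccccc2)cc1` differs from compound 2 by phenyl in place of methyl on a saturated chain carbon bound to an oxygen next to a carbonyl group. Among the compounds with values here, that one step is the only measured change bearing on this part of the molecule, and its small size gives no ground to expect a shift beyond the scatter in this assay in either direction. Compound 3 is therefore expected to give 5000 nM in this assay, with a range from 2000 nM to 12000 nM. The expected step of a 1.1-fold lower number from compound 2 to compound 3 (0.04 log units; within the scatter) is thus read as none beyond the scatter.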

Compound 3, concentration for 50% growth inhibition: 5000 nM
Estimate against measurement, compound 3: no gap at the digits printed; measured number inside the range.
By their numbers in this assay, from the lowest: compounds 1, 3 and 2 (each within the scatter of the next).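

In this assay, phenyl in place of methyl on a saturated chain carbon bound to an oxygen next to a carbonyl group gives a 1.1-fold lower number from compound 2 to compound 3 (0.04 log units; within the scatter), and phenyl in place of pentyl at the same place gives a 1.1-fold higher number from compound 1 to compound 3 (0.04 log units; within the scatter). The earlier compounds shown here carried only saturated chains here, so the new point is that a six-membered aromatic ring of carbon only also leaves the number within the scatter of both chain compounds. Nothing available explains this lack of separation.

On these data alone, whether an amine or a carboxylic acid at this place would give a step beyond the scatter remains open. Also open, as far as these compounds go, is whether a substituted phenyl or a longer chain would do so, and how a change on the shared core would read.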